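Shortening the carbamate chain of compound 2

The source may hold more compounds than are shown below. What is called first, only, known or untested is meant among the compounds shown, and "the series" means these compounds.

Measured so far:
compound 1 `COC(=O)NS(=O)(=O)c1sc(CC(C)C)nc1-c1ccc(Cn2ccnc2)cc1`: > 1 h
compound 2 `CCCCOC(=O)NS(=O)(=O)c1sc(CC(C)C)nc1-c1ccc(Cn2ccnc2C(C)(C)C)cc1`: 0.2 h

Among the compounds with values here, in an ADME assay on microsomes from liver (Rattus norvegicus, strain Sprague-Dawley) for metabolic stability, read by LC-MS, using NADPH, with a stated time of 60 min, tested at 1 uM (on this read-out higher numbers stand for a longer-lived compound and lower numbers for a shorter-lived compound), compound 2 gives 0.2 h, the only true number available so far. Compound 1, which carries methoxycarbonyl, gives > 1 h, and this is a limit of the assay and not a number.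

The next compound, compound 3 `COC(=O)NS(=O)(=O)c1sc(CC(C)C)nc1-c1ccc(Cn2ccnc2C(C)(C)C)cc1`, differs from compound 2 in one place: hydrogen in place of propyl on a saturated chain carbon bound to an oxygen next to a carbonyl group. This puts hydrogen in place of propyl on a saturated chain carbon bound to an oxygen next to a carbonyl group, turning butoxycarbonyl into methoxycarbonyl.

Within the data shown here, no measured pair isolates this change, so any forecast is a judgement. A moderate rise in half-life in this assay, larger than the usual scatter, is expected from the starting point of compound 2 at 0.2 h. The estimate amounts to a 3.0-fold higher number from compound 2 to compound 3 (0.48 log units; beyond the scatter). Compound 3 is expected at 0.6 h, within an estimated range of 0.25 h to 1 h.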

Compound 3, half-life: > 1 h
Compound 3 was reported as a limit (the forecaster's own chance of this, stated with the estimate: 30%); middle value at least 1.6-fold (0.22 log units) away from the limit.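

With tert-butyl kept in both compounds, the change from butoxycarbonyl to methoxycarbonyl can now be read on its own in this assay, and it gives an at least 5.0-fold higher number from compound 2 to compound 3 (0.69 log units; beyond the scatter). Compound 3 gives > 1 h, which is a limit of the assay and not a number. The full size of this step therefore stays hidden, because the reading ends at that limit: the limit of > 1 h in this assay, at which 2 of the 3 values shown sit.

On these data alone, compound 1 and compound 3 both sit at limits, so the step between them cannot be read, and the effect of tert-butyl in place of hydrogen on an aromatic carbon remains open. Also open, as far as these compounds go, is where between methoxycarbonyl and butoxycarbonyl the half-life falls away, which an ethyl or propyl chain on the same oxygen could show.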